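Methoxy for Trifluoromethyl on the Shared Core

The compounds below may be only part of what the source reports. "The series", "measured", "known", "first", "only" and "open" are said of these compounds alone.

Measured so far:
compound 1, `Cc1cccc(-c2nc3ccc(C)cc3c(=O)[nH]2)c1`, giving 75.7% in an assay on isolated protein for inhibition of DNA topoisomerase 1 (Homo sapiens), with a stated time of 30 min, tested at 100 uM; a higher number here means a stronger effect of the compound at the concentration tested, a lower number a weaker effect
compound 2, `Cc1ccc2nc(-c3cccc(C(F)(F)F)c3)[nH]c(=O)c2c1`, giving 45.8% in this assay

Of the compounds shown here, two have been measured in this assay. Compound 1, `Cc1cccc(-c2nc3ccc(C)cc3c(=O)[nH]2)c1`, gives 75.7%. Among the compounds with values here, compound 2, `Cc1ccc2nc(-c3cccc(C(F)(F)F)c3)[nH]c(=O)c2c1`, gives 45.8%; it stands lowest of the two numbers, with compound 1 as its only neighbour, and the step of a number 29.9 percentage points lower from compound 1 to compound 2 (beyond the scatter) lies beyond the scatter.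

Compound 3, `COc1cccc(-c2nc3ccc(C)cc3c(=O)[nH]2)c1`, has not yet been measured. It differs from compound 2 in one place: methoxy in place of trifluoromethyl on an aromatic carbon. Within the data shown here, the only measured step that touches this position is a number 29.9 percentage points lower from compound 1 to compound 2 (beyond the scatter), in which trifluoromethyl took the place of methyl and the number fell by a modest amount. Compound 3 carries neither of those two groups, so that step gives only indirect guidance: it shows the position matters and marks out the span from compound 2 up to compound 1 as the likeliest range. The expected step is therefore an increase, a number 14.2 percentage points higher from compound 2 to compound 3 (beyond the scatter), with wide uncertainty. Compound 3 is estimated to give 60%, between 35% and 85%.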

Compound 3, a percentage reported as inhibition, at one concentration (the size of the read-out at that concentration, not a potency): 71.8%
Compound 3: the middle estimate sits 11.8 percentage points below what was measured, and the stated range covers the measured number.
By their numbers in this assay, from the lowest: compound 2; then compounds 3 and 1 (each within the scatter of the next).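

In this assay, the change back from trifluoromethyl to methoxy gives a number 26 percentage points higher from compound 2 to compound 3 (beyond the scatter) and so recovers the ground lost in the first step, which shows that a new group at this aromatic carbon does not by itself go with a lower number. The comparison with the original methyl group gives a number 3.9 percentage points lower from compound 1 to compound 3 (within the scatter) on the shared core, so methyl and methoxy cannot be told apart here, even though methoxy brings an oxygen and a hydrogen-bond acceptor that methyl lacks, and among these three groups only trifluoromethyl stands apart. No measurement shown here offers an explanation for this difference.

The three compounds do not separate which feature of trifluoromethyl goes with its lower number, and each read-out comes from a single concentration, so it gives no potency for any of them. On these data alone, it also remains open whether a hydroxyl, an amine, a carboxylic acid or a longer chain such as ethoxy on the same carbon would stay level with compound 1 and compound 3 or fall toward compound 2.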